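A few compounds are considered here, and "the series" means these few. Any claim that something is new, unique, unknown or untested is made for them only; others in the source may bear on it.

Measured compounds in a functional assay on Ehrlich cells (Mus musculus) for cytotoxicity, read by trypan blue exclusion, with a stated time of 2 h, tested at 100 ug/mL; a lower number here means a weaker effect, a higher number a stronger effect of the compound at the concentration tested:
compound 1 `CCCCNC(=S)NC1=C(C#N)C(c2ccc(Cl)cc2Cl)C2=C(CCCC2=O)N1c1ccc(S(N)(=O)=O)cc1` gives 40%;
compound 2 `C=CCNC(=S)NC1=C(C#N)C(c2ccc(Cl)cc2Cl)C2=C(CCCC2=O)N1c1ccc(S(N)(=O)=O)cc1` gives 40%;
compound 3 `N#CC1=C(NC(=S)Nc2ccc(Br)cc2)N(c2ccc(S(N)(=O)=O)cc2)C2=C(C(=O)CCC2)C1c1ccc(Cl)cc1Cl` gives 90%.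

Compound 2 stands level with compound 1 at the digits shown, the two together the lowest of the three numbers, while compound 3 lies far above both. Compound 4 `N#CC1=C(NS(=O)(=O)c2ccc(Br)cc2)N(c2ccc(S(N)(=O)=O)cc2)C2=C(C(=O)CCC2)C1c1ccc(Cl)cc1Cl` differs from compound 2 by a group of 10 heavy atoms (6 carbon, 2 oxygen, 1 sulfur, 1 bromine; one six-membered aromatic ring of carbon only) in place of a group of 6 heavy atoms (4 carbon, 1 nitrogen, 1 sulfur; no ring), on an amine nitrogen. The measured steps that bear on this are a number 50 percentage points higher from compound 2 to compound 3 (beyond the scatter) and a number 50 percentage points higher from compound 1 to compound 3 (beyond the scatter), both placing a 4-bromophenyl group where a short chain had been. Compound 4 also carries a 4-bromophenyl group, though attached through a sulfonyl rather than as in compound 3, so a sizeable rise in this assay is expected, yet with less certainty than for compound 3. For compound 4 the expected step is a number 30 percentage points higher from compound 2 to compound 4 (beyond the scatter). Compound 4 is thus estimated at 70%, within a range of 40% to 95%.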

Compound 4, a percentage reported as activity, at one concentration (the size of the read-out at that concentration, not a potency): 100%
Estimate against measurement, compound 4: 30 percentage points below; the measured number lies above the stated range.
By their numbers in this assay, from the lowest: compounds 1 and 2 (each within the scatter of the next); then compounds 3 and 4 (each within the scatter of the next).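

In this assay the (4-bromophenyl)sulfonyl group on this amine nitrogen gives a large gain over the short chains, with a number 60 percentage points higher from compound 2 to compound 4 (beyond the scatter) and a number 60 percentage points higher from compound 1 to compound 4 (beyond the scatter). Set against the bromophenyl-bearing group of compound 3, the same group shows a number 10 percentage points higher from compound 3 to compound 4 (within the scatter), so a sulfonyl link serves here as well as the link in compound 3. No evidence is available on why this group gives such a high read-out. Going by these compounds, whether the bromine is needed remains open, as does the need for the ring: a plain phenylsulfonyl or a methylsulfonyl group would test each.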